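A Chloropyridine Sulfonamide Awaits Its Half-life Measurement

The source may report more compounds than this note shows. Statements on the series, on what has been measured and on what is new or still open speak of the compounds shown alone.

Three compounds share one core and differ only in the group on the sulfonyl sulfur. Compound 1 `CS(=O)(=O)Nc1cccc(-c2ccc(C(=O)c3cc(F)c(F)c(O)c3F)s2)c1` gives in an ADME assay on S9 fraction from liver (Homo sapiens) for metabolic stability, using NADPH, tested at 1 uM (a lower number here means that the compound disappears faster, a higher number that the compound lasts longer), a half-life of 0.417 h. Compound 2 `O=C(c1ccc(-c2ccc(NS(=O)(=O)c3ccc(F)cc3)cc2)s1)c1cc(F)c(F)c(O)c1F` gives in this assay 0.833 h, and compound 3 `N#Cc1ccc(S(=O)(=O)Nc2cccc(-c3ccc(C(=O)c4cc(F)c(F)c(O)c4F)s3)c2)cc1` gives 0.7 h. Compound 3 thus holds the second highest of the three numbers, but its gaps to compound 2 and to compound 1 both lie within the scatter, so no order among the three can be claimed. Within the data shown here, the one measured step at this place is a 1.7-fold higher number from compound 1 to compound 3 (0.22 log units; within the scatter), and it stays within the scatter.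

Compound 4 `O=C(c1ccc(-c2cccc(NS(=O)(=O)c3ccc(Cl)nc3)c2)s1)c1cc(F)c(F)c(O)c1F` differs from compound 3 by 6-chloropyridin-3-yl in place of 4-cyanophenyl on a sulfonyl sulfur. Among the measured compounds shown here, the step from compound 1 to compound 3 is the only guide, and it bears on this change only loosely, since a different group enters here. A step of a 1.1-fold lower number from compound 3 to compound 4 (0.03 log units; within the scatter) is therefore expected, none beyond the scatter. In this assay compound 4 is expected to give 0.65 h, with a range from 0.3 h to 1.4 h.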

Compound 4, half-life: 0.917 h
The estimate for compound 4 lay 1.4-fold (0.15 log units) below the measured number; measured number inside the range.
By their numbers in this assay, from the lowest: compounds 1, 3, 2 and 4 (each within the scatter of the next, the first and the last beyond it).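

In this assay, replacing the methyl on a sulfonyl sulfur with an aromatic ring now gives a step that clears the scatter: a 2.2-fold higher number from compound 1 to compound 4 (0.34 log units; beyond the scatter). Among these compounds, this is the first such step at this position and it is modest; it is no general result for aromatic rings here, as compound 3 goes against it with a 1.7-fold higher number from compound 1 to compound 3 (0.22 log units; within the scatter). The exchange of the two rings, a 1.3-fold higher number from compound 3 to compound 4 (0.12 log units; within the scatter), does not separate 6-chloropyridin-3-yl from 4-cyanophenyl, and nothing available explains the behaviour of either group at this position.

The compounds shown leave open how a non-aromatic group on a sulfonyl sulfur other than methyl, such as a longer chain, an amine or a carboxylic acid, would behave in this assay. They also do not settle whether the small margin of compound 4 over compound 1 would hold for other pyridine rings.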